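This account rests on a few compounds, and the source may have more. Where it says the series, first, only, none or still open, it means among the compounds named here.

Measured in a functional assay on the whole organism (strain albino) with Rattus norvegicus as the target, read by paw edema, with stated times of 1 h and 4 h, at a dose of 25 mg/kg by the oral route; on this read-out lower numbers stand for a weaker effect and higher numbers for a stronger effect at the one dose given:
compound 1 `COc1ccc(Cl)cc1C(=O)Nc1ccc(C2=NN(C)C(c3ccc([N+](=O)[O-])cc3)C2)cc1` gives 93%
compound 2 `COc1ccc(Cl)cc1C(=O)Nc1ccc(C2=NNC(c3ccccc3[N+](=O)[O-])C2)cc1` gives 88.3%

Compound 2 and compound 1 lie within the scatter of each other in this assay, so neither stands apart on the numbers at hand. Compound 3 `COc1ccc(Cl)cc1C(=O)Nc1ccc(C2=NNC(c3ccc([N+](=O)[O-])cc3)C2)cc1` is still unmeasured; against compound 2 the change is 4-nitrophenyl in place of 2-nitrophenyl on a saturated ring carbon. For the measured compounds named here, no step between measured compounds covers this change. Compound 1 also carries 4-nitrophenyl and gives 93%, close to compound 2. The step of a number 1.7 percentage points higher from compound 2 to compound 3 (within the scatter) is therefore expected to stay within the scatter, with no clear direction. Compound 3 is estimated at 90%, with a range from 78% to 98%.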

Compound 3, a percentage reported as activity, at one dose (the size of the read-out at that dose, not a potency): 91.3%
Estimate against measurement, compound 3: 1.3 percentage points below; the measured number falls inside the stated range.
By their numbers in this assay, from the lowest: compounds 2, 3 and 1 (each within the scatter of the next).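

In this assay, 4-nitrophenyl in place of 2-nitrophenyl on the saturated ring carbon gives a number 3 percentage points higher from compound 2 to compound 3 (within the scatter) and so shows that this exchange of nitrophenyl groups does not separate the two compounds at this dose. With 4-nitrophenyl held fixed, hydrogen in place of methyl on the ring nitrogen gives a number 1.7 percentage points lower from compound 1 to compound 3 (within the scatter) and so does not separate them either. No supporting data bear on either step.

Still open, going by these compounds, is whether an aminophenyl or carboxyphenyl group, or an unsubstituted phenyl, on the saturated ring carbon would stand apart from these nitrophenyl compounds. A single dose also leaves open whether any of these compounds would give a stronger or weaker effect at other doses.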